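Swapping methyl for trifluoromethyl at a cytotoxicity limit

The source may report more compounds than this note shows. Statements on the series, on what has been measured and on what is new or still open speak of the compounds shown alone.

Compound 2 `Cc1cccc(NC(=O)c2ccc3cccc(O)c3n2)c1` is the starting point. In an ADME assay on THP-1 cells (Homo sapiens) for cytotoxicity, read by WST assay, with a stated time of 24 h (a lower number here means a stronger inhibitor, a higher number a weaker inhibitor), compound 2 gives only a limit, > 30000 nM. Compound 1 `Cc1ccccc1NC(=O)c1ccc2cccc(O)c2n1` also gives a limit, > 30000 nM. Compound 3 `O=C(Nc1ccc(Br)cc1)c1ccc2cccc(O)c2n1` likewise gives a limit, > 30000 nM. From the compounds shown here alone, because every value sits at the limit of > 30000 nM in this assay, at which 3 of the 3 values shown sit, the steps a step that the two limits leave unreadable from compound 1 to compound 2, a step that the two limits leave unreadable from compound 1 to compound 3 and a step that the two limits leave unreadable from compound 2 to compound 3 cannot be read, so the influence of the amide aryl group on this read-out stays unknown. Compound 4 `O=C(Nc1cccc(C(F)(F)F)c1)c1ccc2cccc(O)c2n1` differs from compound 2 by trifluoromethyl in place of methyl on an aromatic carbon. For the measured compounds named here, with all measured neighbours at the limit, no measured step bears on this change, and compound 4 is expected to remain at the limit, a step that the limit leaves unreadable from compound 2 to compound 4 not expected to exceed the scatter. Compound 4 is estimated at 45000 nM, between 20000 nM and 100000 nM.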

Compound 4, half-maximal inhibitory concentration: > 30000 nM
Compound 4 ended at the assay's limit; the forecaster's own chance of this, stated with the estimate: 85%; the middle value does not contradict the limit.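

For the compounds shown here, compound 2 and compound 4 both stop at the limit of the assay, so no step between them can be read: the limit of > 30000 nM in this assay, at which 4 of the 4 values shown sit. The compounds shown leave open what concentration, if any, would give half-maximal inhibition in this assay.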